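The source may report more compounds than this note shows. Statements on the series, on what has been measured and on what is new or still open speak of the compounds shown alone.

Measured in a functional assay on MCF7 cells (Homo sapiens) for antiproliferative activity, read by MTT assay, with a stated time of 72 h; on this read-out lower numbers stand for stronger inhibition and higher numbers for weaker inhibition:
- compound 1 `C#CCSc1nc(Sc2nc(C)c(C)s2)c(C#N)c(-c2cc(OC)c(OC)c(OC)c2)n1`: > 20000 nM (a limit)
- compound 2 `C#CCSc1nc(Sc2nccs2)c(C#N)c(-c2ccc(Br)cc2)n1`: 11600 nM
- compound 3 `C#CCSc1nc(Sc2nccs2)c(C#N)c(-c2ccc(Cl)cc2)n1`: 3230 nM

Compound 1 stands at the limit of > 20000 nM in this assay, at which 1 of the 3 values shown sits. Compound 4 `C#CCSc1nc(Sc2nc(C)cs2)c(C#N)c(-c2cc(OC)c(OC)c(OC)c2)n1` differs from compound 1 by hydrogen in place of methyl on an aromatic carbon, which turns 4,5-dimethyl-1,3-thiazol-2-yl into 4-methyl-1,3-thiazol-2-yl. Among the compounds with values here, no measured step makes this change. Within the data shown here, the only measured step, a 3.6-fold lower number from compound 2 to compound 3 (0.56 log units; beyond the scatter), is a different exchange and serves only as a yardstick for a small change. In this assay a step no larger than that is expected, towards a lower number if any, and it may stay within the scatter. The expected outcome is a number no higher from compound 1 to compound 4 (the limit leaves the size open). The estimate for compound 4 is 20000 nM, with an expected range from 8000 nM to 40000 nM.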

Compound 4, half-maximal inhibitory concentration: > 20000 nM
Compound 4 ended at the assay's limit; the forecaster's own chance of this, stated with the estimate: 55%; the middle value lies on the limit itself.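

No step can be read from compound 1 to compound 4 in this assay, because both compounds stand at the same limit: the limit of > 20000 nM in this assay, at which 2 of the 4 values shown sit.

The compounds shown leave open what size of change, if any, hydrogen in place of methyl on an aromatic carbon brings in this assay.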